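Acetyl Replaces Arylsulfonyl on the Piperazine Nitrogen

This account rests on a few compounds, and the source may have more. Where it says the series, first, only, none or still open, it means among the compounds named here.

Measured so far in an assay on isolated protein for inhibition of 5-hydroxytryptamine receptor 4 (Homo sapiens); a lower number here means a stronger inhibitor, a higher number a weaker inhibitor:
Compound 1 `CC1(C)CCN(S(=O)(=O)CCCN2CCC(CNC(=O)c3cccc4c3OCCO4)CC2)CC1` gives 0.126 nM.
Compound 2 `O=C(NCC1CCN(CCCS(=O)(=O)N2CCNCC2)CC1)c1cccc2c1OCCO2` gives 0.159 nM.
Compound 3 `O=C(NCC1CCN(CCCS(=O)(=O)N2CCN(S(=O)(=O)c3ccc(F)cc3)CC2)CC1)c1cccc2c1OCCO2` gives 0.0316 nM.

Compound 3 holds the lowest number of the three, separated from compound 1 and from compound 2 beyond the scatter. Compound 4 `CC(=O)N1CCN(S(=O)(=O)CCCN2CCC(CNC(=O)c3cccc4c3OCCO4)CC2)CC1` differs from it by acetyl in place of (4-fluorophenyl)sulfonyl on an amine nitrogen in a ring. Going by the values given here, two measured steps bear on this change. a 1.3-fold higher number from compound 1 to compound 2 (0.10 log units; within the scatter). a 5.0-fold lower number from compound 2 to compound 3 (0.70 log units; beyond the scatter), so the arylsulfonyl group on that ring nitrogen was the only change that moved the number beyond the scatter. Acetyl brings far fewer atoms than the group it replaces, so compound 4 is expected to fall back toward compound 2 but not fully: an estimated 3.2-fold higher number from compound 3 to compound 4 (0.50 log units; beyond the scatter). Compound 4 is therefore expected near 0.1 nM, within 0.03 nM to 0.3 nM.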

Compound 4, inhibition constant: 0.126 nM
Compound 4: the middle estimate sits 1.3-fold (0.10 log units) below what was measured, and the stated range covers the measured number.
By their numbers in this assay, from the lowest: compound 3; then compounds 1, 4 and 2 (each within the scatter of the next).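

In this assay, acetyl on the amine nitrogen in the ring does not keep the level of the (4-fluorophenyl)sulfonyl group, with a 4.0-fold higher number from compound 3 to compound 4 (0.60 log units; beyond the scatter). It also stays level with the unsubstituted ring nitrogen, with a 1.3-fold lower number from compound 2 to compound 4 (0.10 log units; within the scatter), and with the 4,4-dimethylpiperidin-1-yl group, with no change at the digits printed from compound 1 to compound 4 (within the scatter), so a small carbonyl group on this nitrogen does not reproduce the arylsulfonyl step. Nothing available explains this difference.

From the compounds shown here alone, whether benzoyl or methanesulfonyl on the same nitrogen would track with acetyl or with (4-fluorophenyl)sulfonyl remains open. That would separate the contribution of the aromatic ring from that of the sulfonyl link.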